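This account rests on a few compounds, and the source may have more. Where it says the series, first, only, none or still open, it means among the compounds named here.

In an assay on isolated protein for agonist activity at Bile acid receptor (Homo sapiens), read by TR-FRET (a higher number here means that more compound is needed for the effect, a lower number that less compound is needed), compound 3 `CCn1c(-c2ccc(OCc3c(-c4c(Cl)cccc4Cl)noc3C(C)C)cc2)nc2ccc(C(=O)O)cc21` gives 19.3 nM, the lowest of the two numbers recorded. Compound 1 `CCC(CC)n1c(-c2ccc(OCc3c(-c4c(Cl)cccc4Cl)noc3C(C)C)cc2F)nc2ccc(C(=O)O)cc21` gives 69.3 nM, a higher number that lies beyond the scatter; since compound 1 differs from compound 3 in more than one place, only the two values themselves can be compared. For compound 2 `CC(C)c1onc(-c2c(Cl)cccc2Cl)c1COc1ccc(-c2nc3ccc(C(=O)O)cc3n2CC2CCCCC2)c(F)c1` the entry in this assay reads "not determined" (no result reported), that is, no result was reported for compound 2. Compound 4 `CC(C)c1onc(-c2c(Cl)cccc2Cl)c1COc1ccc(-c2nc3ccc(C(=O)O)cc3n2CC2CC2)cc1` differs from compound 3 by cyclopropyl in place of methyl on a saturated chain carbon bound to an aromatic nitrogen. For the measured compounds named here, no step between measured compounds isolates this change, so in this assay only a modest shift is expected for compound 4, at most slightly beyond the scatter and leaning toward a higher number. Compound 4 is estimated to give 30 nM, within 10 nM to 90 nM, which corresponds to an expected step of a 1.6-fold higher number from compound 3 to compound 4 (0.19 log units; within the scatter).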

Compound 4, half-maximal effective concentration: 29.1 nM
Compound 4: middle estimate off by 1.0-fold (0.01 log units), on the high side; measured number inside the range.
By their numbers in this assay, from the lowest: compounds 3 and 4 (each within the scatter of the next); then compound 1.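

In this assay, for the compounds shown here, a 1.5-fold higher number from compound 3 to compound 4 (0.18 log units; within the scatter) gives the first comparison that isolates a single change at this position, since the earlier compounds offered no such step. With cyclopropyl in place of methyl on a saturated chain carbon bound to an aromatic nitrogen, the two compounds cannot be told apart, so ethyl and cyclopropylmethyl serve equally here in this assay. Nothing available gives a reason for this result. The compounds shown leave open whether a group carrying an amine, a hydroxyl or a longer chain at this position would keep the number within the scatter.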